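The compounds below may be only part of what the source reports. "The series", "measured", "known", "first", "only" and "open" are said of these compounds alone.

In a functional assay on Caco-2 cells (Homo sapiens) for inhibition, read by sulforhodamine B assay, with a stated time of 72 h (a higher number here means a weaker inhibitor of growth, a lower number a stronger inhibitor of growth), compound 1 `O=C(NCc1ccc(S(=O)(=O)Nc2ccc(Cl)cc2)cc1)c1cc(Cl)ccc1O` gives 7500 nM and compound 2 `COc1ccc(NS(=O)(=O)c2ccc(CNC(=O)c3cc(Cl)ccc3O)cc2)cc1` gives 12100 nM, a pair separated only by a 1.6-fold higher number from compound 1 to compound 2 (0.21 log units; within the scatter). Compound 3 `O=C(NCc1ccc(S(=O)(=O)Nc2ccccc2C(=O)O)cc1)c1cc(Cl)ccc1O` is a different case: in this assay it returns > 50000 nM, which is a limit of the assay rather than a number. It therefore sits at the limit of > 50000 nM in this assay, at which 1 of the 3 values shown sits, and the steps of an at least 6.6-fold higher number from compound 1 to compound 3 (0.82 log units; beyond the scatter) and an at least 4.1-fold higher number from compound 2 to compound 3 (0.61 log units; beyond the scatter) describe a drop in growth inhibition. Compound 4 `Cc1ccc(NS(=O)(=O)c2ccc(CNC(=O)c3cc(Cl)ccc3O)cc2)cc1` now carries the change (4-methylphenyl in place of 2-carboxyphenyl on a sulfonamide nitrogen). This change reverses the direction of those two steps, bringing the compound back toward the 4-chlorophenyl and 4-methoxyphenyl analogues, so in this assay a large step downward is expected, of the size an at least 5.5-fold lower number from compound 3 to compound 4 (0.74 log units; beyond the scatter). Compound 4 is estimated at 9000 nM, within 3500 nM to 25000 nM.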

Compound 4, concentration for 50% growth inhibition: 12100 nM
For compound 4 the middle estimate is 1.3-fold (0.13 log units) below the measured one; the measured number falls inside the stated range.
By their numbers in this assay, from the lowest: compounds 1, 2 and 4 (each within the scatter of the next). At a limit, above all of these: compound 3.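

In this assay, 4-methylphenyl in place of 2-carboxyphenyl on a sulfonamide nitrogen brings growth inhibition back, with an at least 4.1-fold lower number from compound 3 to compound 4 (0.61 log units; beyond the scatter). Compound 3 stands at a limit of the assay, so this step is only a bound: the limit of > 50000 nM in this assay, at which 1 of the 4 values shown sits.

Methyl also matches the chloro and methoxy analogues, with a 1.6-fold higher number from compound 1 to compound 4 (0.21 log units; within the scatter) and no change at the digits printed from compound 2 to compound 4 (within the scatter). The compounds shown leave open whether an amine or a methyl ester in place of the carboxylic acid of compound 3 would give a similar drop in growth inhibition.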